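The compounds below may be only part of what the source reports. "The series", "measured", "known", "first", "only" and "open" are said of these compounds alone.

Among the compounds with values here, in an ADME assay on MRC5 cells (Homo sapiens) for inhibition, with a stated time of 72 h (a lower number here means that less compound is needed, a higher number that more compound is needed for the effect), compound 1 (`COc1cccc(OC)c1C(=O)Nc1c[nH]nc1C(=O)N[C@H]1CC[C@H](O)CC1`) gives 34000 nM, the only true number so far. Compound 2 (`COc1cccc(OC)c1C(=O)Nc1c[nH]nc1C(=O)NCC1CCCCC1`) gives > 50000 nM, which is a limit of the assay and not a number. Compound 3 (`COc1cccc(OC)c1C(=O)Nc1c[nH]nc1C(=O)NCCN1CCCC1`) gives > 50000 nM, which is also a limit. Compound 3 therefore stands at the limit of > 50000 nM in this assay, at which 2 of the 3 values shown sit, with no measured position of its own.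

Compound 4 (`COc1cccc(OC)c1C(=O)Nc1c[nH]nc1C(=O)NCCCOC(C)C`) carries isopropoxymethyl in place of pyrrolidin-1-yl on a saturated chain carbon, two bonds along the chain from an amide-type nitrogen.

Within the data shown here, no measured step makes this exact exchange. The closest evidence is a step that the two limits leave unreadable from compound 2 to compound 3, which also changes the end of the side chain. Two further steps replace 4-hydroxycyclohexyl: an at least 1.4-fold higher number from compound 1 to compound 2 (0.16 log units; that floor lies within the scatter) and an at least 1.4-fold higher number from compound 1 to compound 3 (0.16 log units; that floor lies within the scatter). Their sizes are floors only, so they set no scale for the new change.

With compound 3 reading > 50000 nM, no step beyond the scatter is expected in this assay, and compound 4 may well report only a limit too. The expected change is a number no higher from compound 3 to compound 4 (the limit leaves the size open). The estimated value for compound 4 is 50000 nM, with an expected range of 25000 nM to 80000 nM.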

Compound 4, half-maximal effective concentration: > 50000 nM
Compound 4 was reported as a limit; the forecaster's own chance of this, stated with the estimate: 65%; the middle value sits exactly at the limit.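

Exchanging pyrrolidin-1-yl for isopropoxymethyl at this place, on a saturated chain carbon two bonds along the chain from an amide-type nitrogen, removes the ring while keeping the heavy-atom and hydrogen-bond acceptor counts, yet this assay gives no readable response: the steps linking compound 2, compound 3 and compound 4 all have limits at both ends and cannot be read. Within the data shown here, the only readable step is an at least 1.4-fold higher number from compound 1 to compound 4 (0.16 log units; that floor lies within the scatter), so 3-isopropoxypropyl adds a floor no larger than the scatter and sets no size for the change from 4-hydroxycyclohexyl. Cyclohexylmethyl, 2-(pyrrolidin-1-yl)ethyl and now an open-chain ether side chain therefore share one reading, leaving compound 1 as the only true number in the series: the limit of > 50000 nM in this assay, at which 3 of the 4 values shown sit.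

Going by these compounds, how far compound 2, compound 3 and compound 4 actually lie from compound 1, which gives 34000 nM, stays unknown. Also open, on these data alone, is how a carboxylic acid, a primary amine or a hydroxyl at the end of an open side chain would read in this assay.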